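Predicting compound 4 from a set of limit values

This account rests on a few compounds, and the source may have more. Where it says the series, first, only, none or still open, it means among the compounds named here.

Compound 1 `Cc1ccc(S(=O)(=O)Nc2ccc(-c3nc4ccccc4o3)cc2)cc1` gives > 63000 nM in an assay on isolated protein for inhibition of malate dehydrogenase, mitochondrial (Sus scrofa), with stated times of 45 min and 30 min (a higher number here means a weaker inhibitor, a lower number a stronger inhibitor), which is a limit of the assay.
Compound 2 `C=Cc1ccc(S(=O)(=O)Nc2ccc3oc(-c4ccccc4)nc3c2)cc1` gives > 63000 nM in this assay, also a limit.
Compound 3 `COc1cccc(S(=O)(=O)Nc2ccc3oc(-c4ccccc4)nc3c2)c1` gives > 63000 nM in this assay, again a limit.

Compound 1 therefore stands not at a measured number but at the limit of this assay, and the same holds for every value shown, since (the limit of > 63000 nM in this assay, at which 3 of the 3 values shown sit). For the measured compounds named here, the only single-point change among the measured compounds, a step that the two limits leave unreadable from compound 2 to compound 3, cannot be read in size, because both of its ends are limits.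

Compound 4 `O=S(=O)(Nc1ccc(-c2nc3ccccc3o2)cc1)c1ccccc1F` differs from compound 1 in one place: 2-fluorophenyl in place of 4-methylphenyl on a sulfonyl sulfur. Going by the values given here, no measured step touches a 2-fluorophenyl or a 4-methylphenyl on a sulfonyl sulfur, and the one step that changes the group on that sulfur is unreadable. Nothing in the data, then, points to compound 4 moving in either direction beyond the scatter of this assay.

On that basis compound 4 is expected to give about 100000 nM in this assay, with a likely range of 30000 nM to 400000 nM. The expected step that the limit leaves unreadable from compound 1 to compound 4 is essentially none, and the most probable outcome is that compound 4 is again reported only as a limit.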

Compound 4, half-maximal inhibitory concentration: > 63000 nM
Compound 4: only a limit was reported; the forecaster's own chance of this, stated with the estimate: 80%; the middle value does not contradict the limit.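

Compound 4 is reported only as a limit, > 63000 nM, in this assay. The change from compound 1 to compound 4 therefore cannot be read in size, because both ends are limits: the limit of > 63000 nM in this assay, at which 4 of the 4 values shown sit.

The compounds shown leave open whether any group on the sulfonyl sulfur, or any change to the shared core, would give a real number in this assay.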